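A few compounds are considered here, and "the series" means these few. Any claim that something is new, unique, unknown or untested is made for them only; others in the source may bear on it.

Compound 1 `N#Cc1cc(Cl)ccc1NC(=O)c1ccc2cccnc2c1O` is one of three measured analogues. In a functional assay on NALM-6 cells (Homo sapiens) for cytotoxicity, read by luminescence and CellTiter-Glo, with a stated time of 3 days (a lower number here means a stronger inhibitor, a higher number a weaker inhibitor), compound 1 gives 280 nM, the lowest of the three numbers. Its nearest neighbour is compound 3 `O=C(Nc1ccc(Cl)cc1)c1ccc2cccnc2c1O`, which gives 380 nM in this assay; the step of a 1.4-fold higher number from compound 1 to compound 3 (0.13 log units; within the scatter) exchanges hydrogen for cyano on an aromatic carbon and lies within the scatter. The furthest is compound 2 `O=C(Nc1ccc(C(F)(F)F)cc1)c1cc(Br)ccc1O`, which gives 1090 nM in this assay; no single change links it to compound 1, so only the two values themselves can be set side by side.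

The unmeasured compound 4 `N#Cc1ccc(NC(=O)c2ccc3cccnc3c2O)c(C#N)c1` differs from compound 1 in one place: cyano in place of chloro on an aromatic carbon. Of the measured steps only a 1.4-fold higher number from compound 1 to compound 3 (0.13 log units; within the scatter) bears on this, and only loosely, since it removes a cyano group rather than putting one in place of chloro. Among the compounds with values here, no measured step swaps chloro for cyano. The account therefore expects no step beyond the scatter in this assay, in either direction, and the range is kept wide for lack of a closer precedent. Compound 4 is estimated at 350 nM, within a range from 140 nM to 900 nM. The step this estimate means, a 1.3-fold higher number from compound 1 to compound 4 (0.10 log units; within the scatter), is expected to stay within the scatter.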

Compound 4, half-maximal inhibitory concentration: 350 nM
For compound 4 middle estimate and measured number coincide at the digits printed; the range from low to high includes it.
By their numbers in this assay, from the lowest: compounds 1, 4 and 3 (each within the scatter of the next); then compound 2.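

In this assay, within the data shown here, the step of a 1.3-fold higher number from compound 1 to compound 4 (0.10 log units; within the scatter) is the first measured change at the position para to a large group, where compounds 1 and 3 both carry chloro, and it lies within the scatter. Here 1 chlorine atom gives way to a cyano group of 2 heavy atoms with 1 hydrogen-bond acceptor, and the number does not move beyond the scatter, whereas the earlier step of a 1.4-fold higher number from compound 1 to compound 3 (0.13 log units; within the scatter) changed only the other aromatic carbon, the one bearing the first cyano group. No measurement on these compounds accounts for this outcome.

With only chloro and cyano seen at this position on the shared core, the compounds shown do not tell whether hydrogen, an amine, a carboxylic acid or a longer chain such as propyl would also stay within the scatter there. Among these compounds, they also leave open whether the exchange of chloro for cyano would behave the same way in a compound with a second group other than cyano on that ring, since compound 1 and compound 4 are the only pair that shows it.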